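Indolyl amide variant of the sulfonyl benzothiazole urea series

A few compounds are considered here, and "the series" means these few. Any claim that something is new, unique, unknown or untested is made for them only; others in the source may bear on it.

Compound 2 `CN1CCN(CCCS(=O)(=O)c2ccc3nc(NC(=O)NC(=O)c4cc(N5CCCC5)ccc4Cl)sc3c2)CC1` gives 3.1 in a physicochemical assay for lipophilicity (on this read-out higher numbers stand for higher lipophilicity and lower numbers for lower lipophilicity), the higher of the two numbers obtained so far. Compound 1 `CCc1ccc(Cl)c(C(=O)NC(=O)Nc2nc3ccc(S(=O)(=O)CCCN4CCN(C)CC4)cc3s2)c1` gives 2.9 in this assay, and the step of a number 0.20 log units higher from compound 1 to compound 2 (within the scatter) separates the pair. Compound 3 `CN1CCN(CCCS(=O)(=O)c2ccc3nc(NC(=O)NC(=O)c4cc5c(ccn5C)cc4Cl)sc3c2)CC1` is not yet measured; it differs from compound 2 in the aryl group on the imide carbonyl: 5-chloro-1-methyl-1H-indol-6-yl in place of 2-chloro-5-(pyrrolidin-1-yl)phenyl on a carbonyl carbon. Within the data shown here, the single measured step concerns a substituent exchange on the aromatic carbon of that same aryl group and stays inside the scatter, so the two values of compounds 1 and 2 show only that the series sits close together with little movement from that exchange. Among the measured compounds shown here, no measured step covers a replacement of the whole aryl group by a fused bicyclic one, so the direction of the change cannot be read from the data. With compound 2 at 3.1 as the only anchor, compound 3 is expected to land near the same level, as a step of a number 0.10 log units higher from compound 2 to compound 3 (within the scatter), with an estimated value of 3.2 and a range of 2.6 to 3.8.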

Compound 3, distribution coefficient: 2.8
Compound 3: the middle estimate sits 0.40 log units above what was measured; measured number inside the range.
By their numbers in this assay, from the lowest: compounds 3, 1 and 2 (each within the scatter of the next).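

Working notes: the exchange of 2-chloro-5-(pyrrolidin-1-yl)phenyl for 5-chloro-1-methyl-1H-indol-6-yl on a carbonyl carbon is the first replacement of the whole aryl group here, and in this assay it gives a number 0.30 log units lower from compound 2 to compound 3 (within the scatter). The exchange of 2-chloro-5-ethylphenyl for the same indolyl group gives a number 0.10 log units lower from compound 1 to compound 3 (within the scatter), so at this place, among these three compounds, neither the swap of a single substituent nor the swap of the whole aryl group for a fused one carries the read-out beyond the scatter. No independent information accompanies these values to account for them.

The compounds shown leave open whether any group at this place can separate the values in this assay beyond the scatter, for example a carboxylic acid or a primary amine on the aryl ring in place of ethyl or pyrrolidin-1-yl. On these data alone, all three compounds share the rest of the structure, so the response to a change elsewhere, such as a longer chain in that shared part, remains open.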